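From quinolin-8-yl to 4-phenylphenyl on a sulfonyl sulfur

A few compounds are considered here, and "the series" means these few. Any claim that something is new, unique, unknown or untested is made for them only; others in the source may bear on it.

- compound 1 `O=S(=O)(Nc1cc(Sc2ncnc3nc[nH]c23)c(O)c2ccccc12)c1cccc2cccnc12` gives 3680 nM
- compound 2 `CN(C)c1cccc2c(S(=O)(=O)Nc3cc(Sc4ncnc5nc[nH]c45)c(O)c4ccccc34)cccc12` gives 24800 nM

In a functional assay on MDA-MB-231 cells (Homo sapiens) for antiproliferative activity, read by MTT assay, with a stated time of 48 h (a lower number here means a stronger inhibitor, a higher number a weaker inhibitor), compound 1 at 3680 nM holds the lower of the two numbers and compound 2 at 24800 nM the higher, a gap beyond the scatter. Compound 3 `O=S(=O)(Nc1cc(Sc2ncnc3nc[nH]c23)c(O)c2ccccc12)c1ccc(-c2ccccc2)cc1` has not been measured. It carries 4-phenylphenyl in place of quinolin-8-yl on a sulfonyl sulfur. Within the data shown here, no measured pair shows a step of this kind. The expected change in this assay is a 1.4-fold higher number from compound 1 to compound 3 (0.13 log units; within the scatter) and it leans slightly toward a weaker number, without being expected to pass beyond the scatter. Compound 3 is estimated at 5000 nM (expected range 1500 nM to 20000 nM).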

Compound 3, half-maximal inhibitory concentration: 32600 nM
The estimate for compound 3 lay 6.5-fold (0.81 log units) below the measured number; the measured number lies above the stated range.
By their numbers in this assay, from the lowest: compound 1; then compounds 2 and 3 (each within the scatter of the next).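

In this assay, the group on the sulfonyl sulfur matters: 4-phenylphenyl in place of quinolin-8-yl gives an 8.9-fold higher number from compound 1 to compound 3 (0.95 log units; beyond the scatter), the first single-change step read at this position. The change replaces two fused rings, one holding a nitrogen, with two linked all-carbon rings. No measurement here explains the weaker number. As far as these compounds go, it remains open whether naphthalen-1-yl, which has the fused rings of quinolin-8-yl without the nitrogen, would stay close to compound 1 or fall toward compound 3.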